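This account rests on a few compounds, and the source may have more. Where it says the series, first, only, none or still open, it means among the compounds named here.

Measured so far: compound 1 `c1ccc(-c2cn[nH]c2)c(NCC2=NCCN2)c1` gives 1.26 nM in an in vitro functional assay on cells (Fibroblast) for agonist activity at Alpha-1A adrenergic receptor (Homo sapiens); a lower number here means that less compound is needed, a higher number that more compound is needed for the effect; compound 2 `Cn1cccc1-c1ccccc1NCC1=NCCN1` gives 20 nM.

Among the compounds with values here, compound 2 holds the highest of the two numbers; the only measured step, a 16-fold higher number from compound 1 to compound 2 (1.20 log units; beyond the scatter), is large and beyond the scatter. Compound 3 `CCn1cccc1-c1ccccc1NCC1=NCCN1` differs from compound 2 by methyl in place of hydrogen on a saturated chain carbon bound to an aromatic nitrogen, which one bond further out reads methyl to ethyl. Within the data shown here, no measured step touches this position, since the single known step swaps the whole aromatic group, so it offers no direct guide. A change within the scatter is expected for compound 3, a 1.3-fold higher number from compound 2 to compound 3 (0.10 log units; within the scatter). Compound 3 is estimated at 25 nM, between 8 nM and 80 nM.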

Compound 3, half-maximal effective concentration: 2.51 nM
The estimate for compound 3 lay 10-fold (1.00 log units) above the measured number; the measured number lies below the stated range.
By their numbers in this assay, from the lowest: compounds 1 and 3 (each within the scatter of the next); then compound 2.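

Methyl in place of hydrogen on a saturated chain carbon bound to an aromatic nitrogen, which reads methyl to ethyl, gives an 8.0-fold lower number from compound 2 to compound 3 (0.90 log units; beyond the scatter) and so shows that this position responds to a change of 1 carbon. The earlier step swapped the whole aromatic group and gave no reading of this position on its own. No evidence at hand accounts for the size of this step.

Still open, from the compounds shown here alone, is whether a longer chain such as propyl continues the direction of this step. Also open, going by these compounds, is how an amine or a carboxylic acid at the end of that chain would read.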